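The source may hold more compounds than are shown below. What is called first, only, known or untested is meant among the compounds shown, and "the series" means these compounds.

Measured compounds in a functional assay on SW1573 cells (Homo sapiens) for inhibition, read by sulforhodamine B assay, with a stated time of 48 h; a higher number here means a weaker inhibitor of growth, a lower number a stronger inhibitor of growth:
compound 1 `COC(=O)[C@@]1(C)CCC=C2[C@@H]1CC[C@@H](C)[C@]2(C)Cc1c[nH]c2ccccc12` gives 7300 nM
compound 2 `COC(=O)[C@@]1(C)CCC=C2[C@@H]1CC[C@@H](C)[C@]2(C)Cc1c[nH]c2ccc(OC)cc12` gives 1300 nM

Compound 1 holds the highest number of the two in this assay; its nearest neighbour is compound 2, reached by a 5.6-fold lower number from compound 1 to compound 2 (0.75 log units; beyond the scatter), a methoxy in place of hydrogen on an aromatic carbon. Compound 3 `COC(=O)[C@@]1(C)CCC=C2[C@@H]1CC[C@@H](C)[C@]2(C)Cc1c[nH]c2c(Cl)cccc12` has not yet been measured. It differs from compound 1 by chloro in place of hydrogen on an aromatic carbon, the chloro sitting on an aromatic carbon of a six-membered aromatic ring of carbon only, part of a fused system of two rings, ortho to a fused ring. For the measured compounds named here, the only measured step that bears on this is a 5.6-fold lower number from compound 1 to compound 2 (0.75 log units; beyond the scatter), which likewise replaces a hydrogen on an aromatic carbon, though the entering group differs. One such step is a thin basis, so a smaller move in the same direction, or none beyond the scatter, is the cautious expectation. Compound 3 is therefore estimated at 4000 nM, within 1500 nM to 12000 nM, which would mean a 1.8-fold lower number from compound 1 to compound 3 (0.26 log units; within the scatter).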

Compound 3, concentration for 50% growth inhibition: 14000 nM
Compound 3: the middle estimate sits 3.5-fold (0.54 log units) below what was measured; the measured number lies above the stated range.
By their numbers in this assay, from the lowest: compound 2; then compounds 1 and 3 (each within the scatter of the next).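

In this assay, chloro in place of hydrogen on an aromatic carbon, ortho to a fused ring, gives a 1.9-fold higher number from compound 1 to compound 3 (0.28 log units; within the scatter) and so produces no clear change from the core of compound 1. Replacing an aromatic hydrogen therefore does not by itself shift the number, as the methoxy change with a 5.6-fold lower number from compound 1 to compound 2 (0.75 log units; beyond the scatter) might have suggested. Nothing available explains this difference between the two changes.

The compounds shown cannot tell whether the outcome depends on the chloro group or on its position, since chloro and methoxy stand at different places on the core. On these data alone, how a methoxy, an amine or a carboxylic acid would behave at this ortho position, and how chloro would behave where compound 2 carries its methoxy, remains open.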